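A few compounds are considered here, and "the series" means these few. Any claim that something is new, unique, unknown or untested is made for them only; others in the source may bear on it.

Compound 1 `O=C(Nc1ccc(Oc2ccnc3[nH]ccc23)c(F)c1)c1cc2cccnc2n(-c2ccc(F)cc2)c1=O` carries a fluoro on the phenyl group of the shared core, and in a functional assay on HT-29 cells (Homo sapiens) for antiproliferative activity, read by MTT assay, with a stated time of 72 h (on this read-out higher numbers stand for weaker inhibition and lower numbers for stronger inhibition), compound 1 gives 36 nM. Compound 2 `O=C(Nc1ccc(Oc2ccnc3[nH]ccc23)c(F)c1)c1cc2cccnc2n(-c2ccc(Cl)cc2)c1=O` has chloro in place of fluoro on an aromatic carbon, and in this assay compound 2 gives 82 nM. Among the compounds with values here, of the two numbers measured so far, compound 2 holds the higher one, and the single step recorded, a 2.3-fold higher number from compound 1 to compound 2 (0.36 log units; beyond the scatter), is modest but beyond the usual scatter. Compound 3 `O=C(Nc1ccc(Oc2ccnc3[nH]ccc23)c(F)c1)c1cc2cccnc2n(-c2ccc(Br)cc2)c1=O` is not yet measured; it differs from compound 2 by bromo in place of chloro on an aromatic carbon, which, cut one bond further out, reads 4-chlorophenyl to 4-bromophenyl. Within the data shown here, only the step from fluoro to chloro bears on this change, and it raised the number modestly. On that basis the expectation for compound 3 in this assay is a further small rise or no change beyond the scatter, an expected step of a 1.5-fold higher number from compound 2 to compound 3 (0.17 log units; within the scatter). The estimated value for compound 3 is 120 nM, with an expected range from 50 nM to 300 nM.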

Compound 3, half-maximal inhibitory concentration: 120 nM
Compound 3: middle estimate and measured number agree at the digits printed; measured number inside the range.
By their numbers in this assay, from the lowest: compound 1; then compounds 2 and 3 (each within the scatter of the next).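

In this assay, putting bromo in place of chloro on the phenyl group gives a 1.5-fold higher number from compound 2 to compound 3 (0.17 log units; within the scatter), so at this position the two halogens cannot be told apart, and the rise seen on going from fluoro to chloro does not clearly continue. The longer step, a 3.3-fold higher number from compound 1 to compound 3 (0.52 log units; beyond the scatter), is modest but beyond the scatter, and with the earlier step, a 2.3-fold higher number from compound 1 to compound 2 (0.36 log units; beyond the scatter), it sets compound 1, the fluoro compound, apart from both others as the most potent of the three. Across all three halogens the position therefore shows only a modest spread, with a single division between fluoro on one side and chloro and bromo on the other, and nothing available here accounts for that division.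

All three compounds carry a single halogen at this one place, para to a large group, so the compounds shown leave open what a plain hydrogen, a methoxy group, an amine or a carboxylic acid would do there. They also leave open whether the same division between the halogens would appear with the halogen moved elsewhere on the phenyl ring.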